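Hydroxamic acid series: methyl to chloro on the aryl ring

The source may hold more compounds than are shown below. What is called first, only, known or untested is meant among the compounds shown, and "the series" means these compounds.

Of the compounds shown here, two have numbers so far. Compound 1 `Cc1ccccc1CN1CC=C(CCC(=O)NO)C1=O` and compound 2 `Cc1ccc(CCCCN2CC=C(CCC(=O)NO)C2=O)cc1` share the hydroxamic acid core and differ in the arm carried on the ring nitrogen. In a functional assay on MDA-MB-231 cells (Homo sapiens) for inhibition, read by sulforhodamine B assay (on this read-out lower numbers stand for stronger inhibition of growth and higher numbers for weaker inhibition of growth), compound 1 gives 1990 nM and compound 2 gives 4150 nM. Within the data shown here, compound 2 therefore stands at the higher of the two numbers, with compound 1 as its nearest neighbour at a gap beyond the usual scatter; no single-point step between them is worked out, as they differ in more than one place.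

Compound 3 `O=C(CCC1=CCN(CCCCc2ccc(Cl)cc2)C1=O)NO` has not been measured. It departs from compound 2 by chloro in place of methyl on an aromatic carbon, the rest of the molecule being unchanged. Among the measured compounds shown here, no measured pair shows this change, so the numbers themselves give no guide to its size in this assay. With one heavy atom leaving and one entering, the step expected in this assay is none beyond the scatter, in either direction. Compound 3 is expected to give about 3500 nM, between 1500 nM and 8000 nM. The expected step is a 1.2-fold lower number from compound 2 to compound 3 (0.07 log units; within the scatter).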

Compound 3, concentration for 50% growth inhibition: 4150 nM
For compound 3 the middle estimate is 1.2-fold (0.07 log units) below the measured one, within the range that was stated.
By their numbers in this assay, from the lowest: compound 1; then compounds 2 and 3 (each within the scatter of the next).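

Among these compounds, the first pair that differs in one place reads, in this assay, no change at the digits printed from compound 2 to compound 3 (within the scatter), for chloro in place of methyl on an aromatic carbon, para to a large group. On this arm, then, 4-methylphenyl and 4-chlorophenyl cannot be told apart on this read-out, and the exchange of one heavy atom for another at this position leaves the number where it stood, something compound 1 and compound 2 could not show, as they differ in more than one place. Nothing at hand bears on why these two groups read alike.

Open, going by these compounds, is whether this position stays as indifferent to groups of another kind, such as an amine, a carboxylic acid or a methoxy group, since a single exchange of methyl for chloro marks out no range of what the position accepts. Also open, on these data alone, is whether the same exchange reads alike on the arm of compound 1, and how much of the gap between compound 1 and compound 2 belongs to the arm's length, which a longer or shorter chain carrying the same 4-methylphenyl would help to separate.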